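Working notes: chain change from compound 3 to compound 4

The source may hold more compounds than are shown below. What is called first, only, known or untested is meant among the compounds shown, and "the series" means these compounds.

Measured so far in a functional assay on HT-29 cells (Homo sapiens) for inhibition, read by sulforhodamine B assay, with a stated time of 72 h; a lower number here means a stronger inhibitor, a higher number a weaker inhibitor:
- compound 1 `COc1cc2c(Nc3ccc(F)c(Cl)c3)ncnc2cc1OCCCn1ccnc1[N+](=O)[O-]` gives 6140 nM
- compound 2 `COc1cc2c(Nc3ccc(F)c(Cl)c3)ncnc2cc1OCCCCCCn1ccnc1[N+](=O)[O-]` gives 5630 nM
- compound 3 `C#Cc1cccc(Nc2ncnc3cc(OCCCCn4ccnc4[N+](=O)[O-])c(OC)cc23)c1` gives 2520 nM

Compound 3 has the lowest number of the three, beyond the scatter from both compound 1 and compound 2. The step under consideration leads to compound 4 `C#Cc1cccc(Nc2ncnc3cc(OCCOCCn4ccnc4[N+](=O)[O-])c(OC)cc23)c1`. The change is 2-(2-nitro-1H-imidazol-1-yl)ethoxy in place of 2-(2-nitro-1H-imidazol-1-yl)ethyl on a saturated chain carbon, two bonds along the chain from an oxygen on an aromatic ring.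

Among the compounds with values here, no measured step matches this change. The nearest one is a 1.1-fold lower number from compound 1 to compound 2 (0.04 log units; within the scatter), a change of chain that stays within the scatter, and compound 1 and compound 2 also differ from compound 3 elsewhere. This is thin support, but no step beyond the scatter is expected in this assay. The expected step is a 1.2-fold higher number from compound 3 to compound 4 (0.08 log units; within the scatter), with no firm direction. Compound 4 is estimated at 3000 nM (expected range 1500 nM to 6000 nM).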

Compound 4, half-maximal inhibitory concentration: 8770 nM
The estimate for compound 4 lay 2.9-fold (0.47 log units) below the measured number, and the stated range ends below it.
By their numbers in this assay, from the lowest: compound 3; then compounds 2, 1 and 4 (each within the scatter of the next).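

In this assay this position responds to what the chain is made of: 2-(2-nitro-1H-imidazol-1-yl)ethoxy in place of 2-(2-nitro-1H-imidazol-1-yl)ethyl gives a 3.5-fold higher number from compound 3 to compound 4 (0.54 log units; beyond the scatter) and so moves the number beyond the scatter. The earlier chain change, a 1.1-fold lower number from compound 1 to compound 2 (0.04 log units; within the scatter) on a different core, stayed within the scatter, so the chain at this oxygen on the aromatic ring is not silent in this series. Nothing available explains the higher number of compound 4.

From the compounds shown here alone, whether the step follows from the added chain oxygen itself or from the longer chain that comes with it stays open. An amine in place of that oxygen, or a longer chain holding the same ether oxygen, would be needed to separate the two, and the step's behaviour on the core of compound 1 is also unknown.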